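A few compounds are considered here, and "the series" means these few. Any claim that something is new, unique, unknown or untested is made for them only; others in the source may bear on it.

Measured in an in vitro ADME assay on microsomes from liver (Simiiformes) (on this read-out higher numbers stand for a longer-lived compound and lower numbers for a shorter-lived compound), each value being a limit of the assay:
- compound 1 `Cc1cc(-c2noc(C3CC3)n2)cc(C)c1OCCCc1cc(CO)no1`: > 2.5 h
- compound 2 `Cc1cc(-c2noc(C3CC3)n2)cc(C)c1OCCCc1cc(OCCO)no1`: > 2.5 h
- compound 3 `CCOc1nc(-c2cc(C)c(OCCCc3cc(C)no3)c(C)c2)no1`: > 2.5 h

Compound 3 therefore offers no exact number, only a limit, and the same is true across the series: the limit of > 2.5 h in this assay, at which 3 of the 3 values shown sit.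

Compound 4 `Cc1cc(CCCOc2c(C)cc(-c3noc(C4CC4)n3)cc2C)on1` differs from compound 3 by one change: cyclopropyl in place of ethoxy on an aromatic carbon. In words, cyclopropyl takes the place of ethoxy on an aromatic carbon.

Among the measured compounds shown here, the only measured step is a step that the two limits leave unreadable from compound 1 to compound 2. It lies elsewhere in the molecule and has no readable size, so it gives no guide to this change. The closest hint comes from the group itself. Compound 1 carries 5-cyclopropyl-1,2,4-oxadiazol-3-yl and reads > 2.5 h, a limit. Compound 2 carries it too and reads > 2.5 h, also a limit.

No drop in this assay is therefore expected, and the expected change is a step that the limit leaves unreadable from compound 3 to compound 4. For compound 4 the estimated half-life is 4 h, with an expected range of 2.5 h to 8 h.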

Compound 4, half-life: 2.23 h
Beside the measured number, compound 4's estimate is 1.8-fold (0.25 log units) above it; measured number below the stated range.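

In this assay, among the compounds shown here, compound 4 is the first compound with an exact number, which puts a lower edge on the change from ethoxy to cyclopropyl on an aromatic carbon: an at least 1.1-fold lower number from compound 3 to compound 4 (0.04 log units; that floor lies within the scatter). Methyl in place of 2-hydroxyethoxy gives an at least 1.1-fold lower number from compound 2 to compound 4 (0.04 log units; that floor lies within the scatter), and hydrogen in place of hydroxy on a saturated chain carbon gives an at least 1.1-fold lower number from compound 1 to compound 4 (0.04 log units; that floor lies within the scatter). All three are floors, so none of them shows a real loss yet, and the other three compounds remain at a limit: the limit of > 2.5 h in this assay, at which 3 of the 4 values shown sit.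

As far as these compounds go, how far compound 1, compound 2 and compound 3 lie past that limit stays open, so the true size of each step is unknown. Also open, from the compounds shown here alone, is how an amine or a cyclobutyl group on the same aromatic carbon would read in this assay.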